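A few compounds are considered here, and "the series" means these few. Any claim that something is new, unique, unknown or untested is made for them only; others in the source may bear on it.

Working notes on the series in a functional assay on K562 cells (Homo sapiens) for inhibition, read by sulforhodamine B assay, with a stated time of 48 h; a lower number here means a stronger inhibitor of growth, a higher number a weaker inhibitor of growth.

Compound 1 `COc1cc2cc(Oc3ccc(NC(=O)Nc4cccc(C(F)(F)F)c4)cc3)c(C)nc2cc1OC` gives 1730 nM in this assay. Compound 2 `COc1cc2cc(Oc3ccc(NC(=O)Nc4ccc(Cl)c(C(F)(F)F)c4)cc3)c(C)nc2cc1OC` carries an added chloro on an aromatic carbon and gives 1110 nM in this assay. Going by the values given here, the step of a 1.6-fold lower number from compound 1 to compound 2 (0.19 log units; within the scatter) lies within the scatter, so the two measured numbers cannot be told apart; compound 2 simply supplies the smaller of the two values, with compound 1 as its only neighbour.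

Compound 3 `COc1cc2cc(Oc3ccc(NC(=O)Nc4ccc(Cl)c(Cl)c4)cc3)c(C)nc2cc1OC` is the next member. It differs from compound 2 by chloro in place of trifluoromethyl on an aromatic carbon. Among the compounds with values here, no measured step exchanges a trifluoromethyl for a chloro; the only step available, a 1.6-fold lower number from compound 1 to compound 2 (0.19 log units; within the scatter), adds a chloro at another carbon and stays within the scatter. Within the data shown here, the change from compound 2 to compound 3 therefore has no direct precedent here, and the one related step gives no reason to expect a shift beyond the scatter in this assay.

The step of a 1.0-fold lower number from compound 2 to compound 3 (0.00 log units; within the scatter) is the expected outcome. Compound 3 is estimated at 1100 nM in this assay, within a range of 500 nM to 2500 nM.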

Compound 3, concentration for 50% growth inhibition: 3320 nM
For compound 3 the middle estimate is 3.0-fold (0.48 log units) below the measured one; the measured number lies above the stated range.
By their numbers in this assay, from the lowest: compounds 2, 1 and 3 (each within the scatter of the next, the first and the last beyond it).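

In this assay, going by these compounds alone, this carbon, ortho to a chloro group, gives the first step that passes the scatter: a 3.0-fold higher number from compound 2 to compound 3 (0.48 log units; beyond the scatter) when chloro takes the place of trifluoromethyl, so with that other chloro group in place the two groups can be told apart, though the step is modest. The wider exchange, with 3,4-dichlorophenyl in place of 3-(trifluoromethyl)phenyl, gives a 1.9-fold higher number from compound 1 to compound 3 (0.28 log units; within the scatter) and does not separate those two compounds, so the difference so far appears only against the 4-chloro-3-(trifluoromethyl)phenyl group. Nothing available on these compounds bears on the origin of the step.

Still open, going by these compounds, is where other groups on this carbon, such as a nitrile, a methoxy or a bromo, would fall relative to trifluoromethyl and chloro in this assay on the same shared core. Also open, on these data alone, is whether the exchange of trifluoromethyl for chloro gives a step of similar size when the other chloro group is replaced by a fluoro or a methyl.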